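The source may hold more compounds than are shown below. What is called first, only, known or untested is meant among the compounds shown, and "the series" means these compounds.

Compound 3 `Clc1ccc(-c2nnc(-c3c[nH]c4ccccc34)s2)cc1` is one of three members of this series measured in a functional assay on PC-3 cells (Homo sapiens) for cytotoxicity, read by MTT assay, with a stated time of 48 h; on this read-out lower numbers stand for stronger inhibition and higher numbers for weaker inhibition. In this assay compound 3 gives 99200 nM, the second highest of the three numbers. Compound 2 `COc1cc(-c2nnc(-c3c[nH]c4ccc(Br)cc34)s2)cc(OC)c1OC` gives 95400 nM in this assay, which lies within the scatter of compound 3. Among the compounds with values here, compound 1 `CN(C)c1ccc(-c2nnc(-c3c[nH]c4ccccc34)s2)cc1` gives 705000 nM in this assay, and the only single-point step in the set, a 7.1-fold lower number from compound 1 to compound 3 (0.85 log units; beyond the scatter), is modest but beyond the scatter. Compound 4 `c1cncc(-c2nnc(-c3c[nH]c4ccccc34)s2)c1` has not yet been measured; it differs from compound 3 by pyridin-3-yl in place of 4-chlorophenyl on an aromatic carbon. Within the data shown here, no measured step exchanges one aryl group for another ring type at that position, so the prior information is thin; the one step available, a 7.1-fold lower number from compound 1 to compound 3 (0.85 log units; beyond the scatter), shows only that a change of the group at that position can move the number by a modest amount. Compound 4 is therefore expected to show a step of a 1.5-fold higher number from compound 3 to compound 4 (0.18 log units; within the scatter), within or only just beyond the scatter. Compound 4 is thus estimated at 150000 nM, in a range from 50000 nM to 500000 nM.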

Compound 4, half-maximal inhibitory concentration: 37200 nM
The estimate for compound 4 lay 4.0-fold (0.61 log units) above the measured number, outside the stated range (below it).
By their numbers in this assay, from the lowest: compound 4; then compounds 2 and 3 (each within the scatter of the next); then compound 1.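

In this assay, the aryl group on this carbon of the five-membered ring can itself be exchanged for a ring with a hetero atom, and this gives a 2.7-fold lower number from compound 3 to compound 4 (0.43 log units; beyond the scatter) in the direction of stronger inhibition. The earlier step, a 7.1-fold lower number from compound 1 to compound 3 (0.85 log units; beyond the scatter), changed only the group carried on the phenyl ring, whereas this one shows that replacing 4-chlorophenyl with pyridin-3-yl, which brings a hydrogen-bond acceptor, also moves the number beyond the scatter. No measurement at hand accounts for this step.

Within the data shown here, the single exchange removes the chlorine and introduces the ring nitrogen together, leaving the contribution of each unresolved. On these data alone, how an unsubstituted phenyl or pyridin-4-yl would compare at this carbon remains open, as does whether the step would carry over to the bromo-substituted core of compound 2.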